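This account rests on a few compounds, and the source may have more. Where it says the series, first, only, none or still open, it means among the compounds named here.

The measured compounds in this set are three. Compound 1, `O=c1ccoc2cc(OCc3cn(Cc4ccccc4Br)nn3)ccc12`, in a functional assay on QGY7701 cells (Homo sapiens) for cytotoxicity, read by MTT assay, with a stated time of 48 h (a higher number here means a weaker inhibitor, a lower number a stronger inhibitor), reaches only a limit of the assay, > 100000 nM. Compound 2, `O=c1ccoc2cc(OCc3cn(Cc4cccc(Br)c4)nn3)ccc12`, gives in this assay the value 17600 nM. Compound 3, `CC(C)(C)c1ccc(Cn2cc(COc3ccc4c(=O)ccoc4c3)nn2)cc1`, reaches in this assay only a limit of the assay, > 100000 nM.

Among the measured compounds shown here, compound 2 therefore stands as the only compound with an actual number in this assay; the two other values are limits, and two of the three values sit at the limit of > 100000 nM in this assay, at which 2 of the 3 values shown sit. For the measured compounds named here, the single measured step, an at least 5.6-fold lower number from compound 1 to compound 2 (0.75 log units; beyond the scatter), moves from a limit to a number, so its true size is not fixed.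

Compound 4, `COc1ccc(Cn2cc(COc3ccc4c(=O)ccoc4c3)nn2)cc1`, differs from compound 2 by 4-methoxyphenyl in place of 3-bromophenyl on a saturated chain carbon bound to an aromatic nitrogen. Going by the values given here, no measured step exchanges a bromine-bearing ring for a methoxy-bearing one, so the step from compound 1 to compound 2 bears on it only by showing that the ring at this place can shift the value beyond the scatter. Compound 3, which carries a 4-tert-butylphenyl at the same place, sits at the limit, and the two limits among three values suggest that a weaker inhibitor than compound 2 is the more likely outcome. Compound 4 is expected to give about 80000 nM, between 20000 nM and 300000 nM. This estimate means an expected step of a 4.5-fold higher number from compound 2 to compound 4 (0.66 log units; beyond the scatter).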

Compound 4, half-maximal inhibitory concentration: 56600 nM
Estimate against measurement, compound 4: 1.4-fold (0.15 log units) above, and the stated range covers the measured number.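

In this assay, among the compounds shown here, the step of a 3.2-fold higher number from compound 2 to compound 4 (0.51 log units; beyond the scatter) is the first at this place, on a saturated chain carbon bound to an aromatic nitrogen, that joins two actual numbers, so its size is fixed in a way the earlier step from a limit could not show. It also shows that a change from 3-bromophenyl to 4-methoxyphenyl leaves a readable value in this assay, though a higher one, so a substituted ring here need not end at a limit. The steps of an at least 1.7-fold lower number from compound 3 to compound 4 (0.24 log units; that floor lies within the scatter) and an at least 1.7-fold lower number from compound 1 to compound 4 (0.24 log units; that floor lies within the scatter) start from limits, and their floors set no order for compound 4 against compound 3 or compound 1.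

The compounds shown leave open how far compound 1 and compound 3 actually lie from compound 4: the limit of > 100000 nM in this assay, at which 2 of the 4 values shown sit. They also leave open whether the step from compound 2 to compound 4 comes from the change of group or of its ring place, which change together, and how an amine or a carboxylic acid on this ring would read.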